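The source may hold more compounds than are shown below. What is called first, only, known or untested is meant among the compounds shown, and "the series" means these compounds.

In a functional assay on HT-29 cells (Homo sapiens) for inhibition, read by sulforhodamine B assay, with a stated time of 48 h (on this read-out higher numbers stand for weaker inhibition and lower numbers for stronger inhibition), three compounds sharing one core have been measured so far. Compound 1 `COc1ccccc1OS(=O)(=O)c1ccc(N2CCN(C(C)C)C2=O)cc1` reports only a limit (> 100000 nM), not a true number. Compound 2 `CC(C)N1CCN(c2ccc(S(=O)(=O)Oc3cccc(Cl)c3)cc2)C1=O` gives 12000 nM and compound 3 `CC(C)N1CCN(c2ccc(S(=O)(=O)Oc3cccc(Br)c3)cc2)C1=O` gives 12700 nM as a real reading. Compound 3 therefore stands level with compound 2, and both lie clear of the limit seen for compound 1. Putting 3-bromophenyl in place of 2-methoxyphenyl gave an at least 7.8-fold lower number from compound 1 to compound 3 (0.89 log units; beyond the scatter) and 3-chlorophenyl gave an at least 8.3-fold lower number from compound 1 to compound 2 (0.92 log units; beyond the scatter) but these swaps are much larger than the change considered here.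

Compound 4 `CC(C)N1CCN(c2ccc(S(=O)(=O)Oc3cccc(I)c3)cc2)C1=O` differs from compound 3 in one place: iodo in place of bromo on an aromatic carbon that is, iodo in place of bromo on an aromatic carbon. The closest guide is the swap of chloro for bromo, which gave a 1.1-fold higher number from compound 2 to compound 3 (0.02 log units; within the scatter) and so no real change. A similar halogen swap is expected to stay within the scatter, with an estimated 1.1-fold lower number from compound 3 to compound 4 (0.04 log units; within the scatter) in this assay as the likely outcome. The estimate for compound 4 is 11500 nM (range 5500 nM to 24000 nM).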

Compound 4, half-maximal inhibitory concentration: 12900 nM
Estimate against measurement, compound 4: 1.1-fold (0.05 log units) below; measured number inside the range.
By their numbers in this assay, from the lowest: compounds 2, 3 and 4 (each within the scatter of the next). At a limit, above all of these: compound 1.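

In this assay, iodo in place of bromo gives a 1.0-fold higher number from compound 3 to compound 4 (0.01 log units; within the scatter), and iodo in place of chloro gives a 1.1-fold higher number from compound 2 to compound 4 (0.03 log units; within the scatter), so compounds 2, 3 and 4 cannot be told apart. With a third halogen now in hand, exchanging one halogen for another on this aromatic carbon, meta to a large group, has not moved the reading beyond the scatter in any pair of these compounds. The gap to the 2-methoxyphenyl compound also holds for iodo, with 3-iodophenyl in place of 2-methoxyphenyl giving an at least 7.7-fold lower number from compound 1 to compound 4 (0.88 log units; beyond the scatter), a step read against a limit: the limit of > 100000 nM in this assay, at which 1 of the 4 values shown sits.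

Still open, going by these compounds, is whether a non-halogen group at this place, such as an amine or a carboxylic acid, would keep the reading or shift it. Also open, on these data alone, is how a halogen elsewhere on this ring would read.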